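Swapping the 3-hydroxyphenyl group of compound 3

A few compounds are considered here, and "the series" means these few. Any claim that something is new, unique, unknown or untested is made for them only; others in the source may bear on it.

Measured in an ADME assay on NHDF cells (Homo sapiens) for cytotoxicity, read by MTT assay, with a stated time of 72 h; on this read-out lower numbers stand for stronger inhibition and higher numbers for weaker inhibition:
- compound 1 `COc1cccc(/C=C2\CCC/C(=C\c3ccccc3Cl)C2=O)c1OC`: 44200 nM
- compound 2 `COc1cccc(/C=C2\CCC/C(=C\c3cccc(O)c3)C2=O)c1OC`: 19300 nM
- compound 3 `COc1ccc(/C=C2\CCC/C(=C\c3cccc(O)c3)C2=O)cc1OC`: 6800 nM

Among these three, compound 3 has the lowest number, at 6800 nM. Compound 2 stands higher at 19300 nM, and compound 1 stands highest at 44200 nM.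

The next compound is compound 4 `COc1cc(/C=C2\CCC/C(=C\c3ccc(OC)c(OC)c3)C2=O)ccc1O`, not yet measured. It carries 4-hydroxy-3-methoxyphenyl in place of 3-hydroxyphenyl on a double-bonded chain carbon bound to a double-bonded ring carbon.

Going by the values given here, only one measured step touches this place: a 2.3-fold lower number from compound 1 to compound 2 (0.36 log units; beyond the scatter). That step was modest, and it brought in the group that now leaves, so it offers only indirect guidance. Among the compounds with values here, no measured step shows what the entering group does. A modest move either way in this assay remains possible, but no step beyond the scatter is expected.

The estimate means a 1.1-fold lower number from compound 3 to compound 4 (0.05 log units; within the scatter), an expected change that stays within the scatter. For compound 4 the estimated value is 6000 nM, with an expected range from 2000 nM to 18000 nM.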

Compound 4, half-maximal inhibitory concentration: 13700 nM
Beside the measured number, compound 4's estimate is 2.3-fold (0.36 log units) below it; the measured number falls inside the stated range.
By their numbers in this assay, from the lowest: compounds 3, 4 and 2 (each within the scatter of the next, the first and the last beyond it); then compound 1.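

In this assay, the exchange of 3-hydroxyphenyl for 4-hydroxy-3-methoxyphenyl gives a 2.0-fold higher number from compound 3 to compound 4 (0.30 log units; within the scatter). The earlier step at this place, from a 2-chlorophenyl group to 3-hydroxyphenyl, lay beyond the scatter; this one shows that two hydroxy-bearing phenyl groups can be exchanged here without a change the assay can separate, even though the entering group has more heavy atoms and one more hydrogen-bond acceptor. Nothing available explains this result. The compounds shown leave open whether a phenyl group carrying an amine or a carboxylic acid at this place would stay within the scatter as well. They also leave open whether 4-hydroxy-3-methoxyphenyl would read the same way when paired with the other dimethoxyphenyl group of compound 2.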